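The compounds below may be only part of what the source reports. "The series", "measured", "known", "first", "only" and "open" are said of these compounds alone.

Measured in a functional assay on KB cells (Homo sapiens) for inhibition, read by MTT assay, with a stated time of 24 h, tested at 100 ug/mL; a higher number here means more inhibition of growth at the concentration tested, a lower number less inhibition of growth:
- compound 1 `O=C(CCCCC(S)CCS)NO` gives 58%
- compound 2 `O=C(CCCCC1CCSS1)Nc1ccc(Cl)cn1` gives 74.5%
- compound 3 `O=C(CCCCC1CCSS1)Nc1ccc(Br)cn1` gives 42.3%

Compound 1 stands second of these three, below compound 2 and above compound 3. Compound 4 `O=C(CCCCC(S)CCS)Nc1ccccc1` differs from compound 1 by phenyl in place of hydroxy on an amide-type nitrogen. Among the compounds with values here, no measured step makes this change. The only one, a number 32.2 percentage points lower from compound 2 to compound 3 (beyond the scatter), is bromo in place of chloro on an aromatic carbon, and it shows how far values can move within one series. Compound 2 and compound 3 also carry an aromatic ring on that nitrogen, though on a different core, and their values lie on either side of compound 1. The expected change is therefore no step beyond the scatter, an estimated a number 3 percentage points lower from compound 1 to compound 4 (within the scatter). For compound 4 the estimate is 55%, with an expected range from 35% to 75%.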

Compound 4, percent growth inhibition at one concentration: 15.8%
The estimate for compound 4 lay 39.2 percentage points above the measured number; the measured number lies below the stated range.
By their numbers in this assay, from the lowest: compound 4; then compound 3; then compound 1; then compound 2.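

On the amide-type nitrogen, phenyl in place of hydroxy gives, in this assay, a number 42.2 percentage points lower from compound 1 to compound 4 (beyond the scatter) with the rest of the structure unchanged. Within the data shown here, the only earlier step concerned a halogen on an aromatic carbon, whereas this one shows that the group on the amide-type nitrogen itself can carry a large change in this read-out. No measurement at hand offers an explanation for this step. The compounds shown leave open how a methyl or an amine on that nitrogen would compare with hydroxy and phenyl, and whether a chloro group on the phenyl of compound 4 would change its number.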